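The source may hold more compounds than are shown below. What is called first, only, known or untested is meant among the compounds shown, and "the series" means these compounds.

Measured so far in an assay on isolated protein for inhibition of serine/threonine-protein kinase TNNI3K (Homo sapiens); on this read-out lower numbers stand for stronger inhibition and higher numbers for weaker inhibition:
- compound 1 `Nc1cc(Oc2ccc(NC(=O)Nc3cccc(C(F)(F)F)c3)cc2)ncn1`: 25 nM
- compound 2 `O=C(Nc1ccc(Oc2ccncn2)cc1)Nc1cccc(C(F)(F)F)c1`: 160 nM
- compound 3 `Cc1cc(Oc2ccc(NC(=O)Nc3cccc(C(F)(F)F)c3)cc2)ncn1`: 160 nM

Compound 3 stands level with compound 2 at the digits recorded, the two together giving the highest numbers of the three; the step of no change at the digits printed from compound 2 to compound 3 (within the scatter) lies within the scatter, so no order between them can be read. The one clear separation in the set is a 6.4-fold higher number from compound 1 to compound 3 (0.81 log units; beyond the scatter), matched in size by a 6.4-fold higher number from compound 1 to compound 2 (0.81 log units; beyond the scatter): compound 1 alone, carrying the amino group, gives the markedly lower number.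

Compound 4 `O=C(Nc1ccc(Oc2cc(NCCO)ncn2)cc1)Nc1cccc(C(F)(F)F)c1` is the next member to be measured. Its difference from compound 3: (2-hydroxyethyl)amino in place of methyl on an aromatic carbon

The step that bears on this change is a 6.4-fold higher number from compound 1 to compound 3 (0.81 log units; beyond the scatter), read in reverse: replacing methyl by a group attached through nitrogen at this position of the shared core brought a substantially lower number. Going by the values given here, the incoming (2-hydroxyethyl)amino keeps a nitrogen attachment at the same place but adds a chain of 2 carbon and 1 oxygen, for which no measured step exists. The expectation for this assay is therefore a step downward from compound 3 of moderate size, on the order of a 4.0-fold lower number from compound 3 to compound 4 (0.60 log units; beyond the scatter), though the exact extent is uncertain. For compound 4 the estimated value is 40 nM, expected to fall between 15 nM and 120 nM.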

Compound 4, half-maximal inhibitory concentration: 32 nM
Compound 4: middle estimate off by 1.3-fold (0.10 log units), on the high side; low and high end bracket the measured number.
By their numbers in this assay, from the lowest: compounds 1 and 4 (each within the scatter of the next); then compounds 2 and 3 (each within the scatter of the next).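

In this assay, the position next to the ring nitrogen accommodates more than a bare amino group: with (2-hydroxyethyl)amino, the data show a clear step down from methyl (a 5.0-fold lower number from compound 3 to compound 4 (0.70 log units; beyond the scatter)) and from hydrogen (a 5.0-fold lower number from compound 2 to compound 4 (0.70 log units; beyond the scatter)). Adding 2-hydroxyethyl to the amino nitrogen gives a step within the scatter (a 1.3-fold higher number from compound 1 to compound 4 (0.11 log units; within the scatter)), so no order can be read between these two nitrogen-attached groups, and the extended chain shows no measurable loss relative to amino. Across all four compounds, the two with a nitrogen attachment at this position have lower numbers than the two with hydrogen or methyl, with no compound going against this, but nothing at hand explains the pattern.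

Open, on these data alone, is whether the terminal hydroxyl contributes at all, which a plain ethylamino group or a longer 3-hydroxypropylamino chain would address. Also open, as far as these compounds go, is whether the attaching nitrogen or its hydrogen is needed, a question for a methoxy group, joined through oxygen, and a dimethylamino group, whose nitrogen carries no hydrogen.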